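Cytotoxicity Outlook for a Difluorohydroxypropyl Analogue

The compounds below may be only part of what the source reports. "The series", "measured", "known", "first", "only" and "open" are said of these compounds alone.

In an ADME assay on HEp-2 cells (Homo sapiens) for cytotoxicity, with a stated time of 4 days (a higher number here means that more compound is tolerated, a lower number that less compound is tolerated), compound 1 `CS(=O)(=O)CCCn1c(Cn2cc(S(C)(=O)=O)c3ccncc32)nc2cc(Cl)ccc21` reaches only the limit of the assay, > 100000 nM. Compound 2 `CC(C)(O)CCn1c(Cn2nc(S(C)(=O)=O)c3ccncc32)nc2cc(Cl)ccc21` likewise gives a limit in this assay, > 100000 nM. Compound 3 `CC(C)(CO)Cn1c(Cn2nc(S(C)(=O)=O)c3ccncc32)nc2cc(Cl)ccc21` stands at a limit too, > 100000 nM. The step that the two limits leave unreadable from compound 2 to compound 3 is unreadable; both of its ends are limits. For the measured compounds named here, the only evidence across the series is the limit of > 100000 nM in this assay, at which 3 of the 3 values shown sit, which places every measured compound at the same limit. Compound 4 `CS(=O)(=O)c1nn(Cc2nc3cc(Cl)ccc3n2CCC(O)C(F)F)c2cnccc12` differs from compound 3 by 3,3-difluoro-2-hydroxypropyl in place of 1-(hydroxymethyl)-1-methylethyl on a saturated chain carbon bound to an aromatic nitrogen. Going by the values given here, no measured step bears directly on this change, since a step that the two limits leave unreadable from compound 2 to compound 3 is itself unreadable, and the values shown give no ground to expect a step beyond the scatter in either direction. Compound 4 is therefore expected to sit at the limit of this assay as well, with an estimated half-maximal cytotoxic concentration of 100000 nM (range 50000 nM to 200000 nM). The expected step of a number no higher from compound 3 to compound 4 (the limit leaves the size open) is accordingly estimated as none beyond the scatter.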

Compound 4, half-maximal cytotoxic concentration: > 100000 nM
Compound 4 ended at the assay's limit (the forecaster's own chance of this, stated with the estimate: 85%); the middle value lies on the limit itself.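

In this assay compound 4 gives > 100000 nM, which is a limit of the assay. Its steps from compound 2 and compound 3, both also at that limit, cannot be read. The compounds shown leave open what half-maximal cytotoxic concentration any of them actually has, and so whether these side chains differ at all.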